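The compounds below may be only part of what the source reports. "The series", "measured", "known", "first", "only" and "open" are said of these compounds alone.

Measured in a functional assay on HepG2 cells (Homo sapiens) for antiproliferative activity, read by MTT assay; a higher number here means a weaker inhibitor, a lower number a stronger inhibitor:
- compound 1 `COc1ccc(-c2ccnc(Nc3ccc([N+](=O)[O-])cc3)n2)cc1`: 1040 nM
- compound 2 `COc1ccc(-c2ccnc(Nc3ccc(Cl)cc3Cl)n2)cc1`: 190 nM
- compound 3 `Clc1ccc(Nc2nccc(-c3ccc(Cl)cc3Cl)n2)c(Cl)c1`: 8080 nM

Compound 1 stands in the middle of these three numbers, with compound 2 lower and compound 3 higher, each gap beyond the scatter. Compound 4 `O=[N+]([O-])c1ccc(Nc2nccc(-c3ccc(Br)cc3)n2)cc1` keeps the core of compound 1 but has bromo in place of methoxy on an aromatic carbon. Within the data shown here, no measured pair shows this swap alone, so the expectation is loose. Among the measured compounds shown here, compound 3, the only measured compound without methoxy, gives 8080 nM, but it also differs from compound 1 elsewhere. A small rise in this assay is expected, near the edge of the scatter: a 1.9-fold higher number from compound 1 to compound 4 (0.28 log units; within the scatter). For compound 4 the estimated value is 2000 nM, with an expected range of 500 nM to 8000 nM.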

Compound 4, half-maximal inhibitory concentration: 43000 nM
Beside the measured number, compound 4's estimate is 22-fold (1.33 log units) below it, outside the stated range (above it).
By their numbers in this assay, from the lowest: compound 2; then compound 1; then compound 3; then compound 4.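

Putting bromo in place of methoxy on this aromatic carbon, with the rest of the molecule unchanged, gives a 41-fold higher number from compound 1 to compound 4 (1.62 log units; beyond the scatter) in this assay. Among these compounds, this is the first pair to isolate a single change, and its large step shows that the number depends strongly on the group held at this position. Nothing measured here explains the step.

This single pair cannot show whether a group such as an amine or a hydroxyl at this position would fall nearer compound 1 or compound 4. On these data alone, whether the same swap would have as large an effect on compound 2 also stays open.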